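The source may report more compounds than this note shows. Statements on the series, on what has been measured and on what is new or still open speak of the compounds shown alone.

Measured so far in an ADME assay on J774 cells (Mus musculus) for cytotoxicity, read by resazurin assay, with a stated time of 72 h; a lower number here means that less compound is tolerated, a higher number that more compound is tolerated:
compound 1 `C/C(=N\Nc1nc(CCl)cs1)c1ccc(Cl)c(Cl)c1`: > 50000 nM, a limit of the assay
compound 2 `C/C(=N\Nc1nc(-c2ccc(F)cc2)cs1)c1ccc(Cl)c(Cl)c1`: > 50000 nM, a limit of the assay

Compound 2 stands at the limit of > 50000 nM in this assay, at which 2 of the 2 values shown sit. Within the data shown here, the only measured step, a step that the two limits leave unreadable from compound 1 to compound 2, gives no readable size. Compound 3 `COc1ccc(-c2csc(N/N=C(\C)c3ccc(Cl)c(Cl)c3)n2)cc1` differs from compound 2 by methoxy in place of fluoro on an aromatic carbon. Among the measured compounds shown here, no measured step bears on this change, and both values shown are limits, so no direction in this assay can be read. Compound 3 is expected to sit near 50000 nM, between 20000 nM and 120000 nM. The expected step from compound 2 is a number no higher from compound 2 to compound 3 (the limit leaves the size open), within scatter.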

Compound 3, half-maximal cytotoxic concentration: > 50000 nM
Compound 3: a limit, no number; the forecaster's own chance of this, stated with the estimate: 70%; the middle value sits exactly at the limit.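

No step among compound 1, compound 2 and compound 3 can be read in this assay since all three values are limits: the limit of > 50000 nM in this assay, at which 3 of the 3 values shown sit.

The compounds shown leave open where any of them reaches its half-maximal cytotoxic concentration, and whether exchanging chloromethyl, 4-fluorophenyl or 4-methoxyphenyl changes it.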